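Chloro for Fluoro on a Thiazolyl Amide Core

The source may hold more compounds than are shown below. What is called first, only, known or untested is meant among the compounds shown, and "the series" means these compounds.

Compound 1 `Cc1cc(NC(=O)Cn2cc(-c3ccc(Cl)cc3)nn2)no1`: 1910 nM
Compound 2 `Cc1cc(NC(=O)Cn2cc(-c3ccc(F)cc3)nn2)no1`: a limit of the assay, > 30000 nM
Compound 3 `O=C(Cn1cc(-c2ccc(F)cc2)nn1)Nc1nccs1`: 190 nM

In a functional assay on BMDM cells (Mus musculus, strain C57BL/6) for inhibition, with a stated time of 2 days (on this read-out higher numbers stand for weaker inhibition and lower numbers for stronger inhibition), compound 3 gives 190 nM, a lower number than compound 1 with 1910 nM. For compound 2 the assay reports only a limit, > 30000 nM (the limit of > 30000 nM in this assay, at which 1 of the 3 values shown sits). The two cores differ as told by 1,3-thiazol-2-yl in place of 5-methyl-1,2-oxazol-3-yl on an amide-type nitrogen, a change that gives an at least 150-fold lower number from compound 2 to compound 3 (2.19 log units; beyond the scatter). On the core of compound 2 the change chloro in place of fluoro on an aromatic carbon gives an at least 15-fold lower number from compound 2 to compound 1 (1.19 log units; beyond the scatter).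

Compound 4 `O=C(Cn1cc(-c2ccc(Cl)cc2)nn1)Nc1nccs1` is not yet measured. It differs from compound 3 by chloro in place of fluoro on an aromatic carbon, the same change as that from compound 2 to compound 1, made here on the core of compound 3. Because the earlier step of an at least 15-fold lower number from compound 2 to compound 1 (1.19 log units; beyond the scatter) started from a limit, its true size is not known, and compound 3 already stands low in this assay; a smaller step is therefore expected, a 3.2-fold lower number from compound 3 to compound 4 (0.50 log units; beyond the scatter). Compound 4 is thus estimated at 60 nM in this assay, within a range of 20 nM to 200 nM.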

Compound 4, half-maximal inhibitory concentration: 1100 nM
For compound 4 the middle estimate is 18-fold (1.26 log units) below the measured one, outside the stated range (above it).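

In this assay the change from 4-fluorophenyl to 4-chlorophenyl does not carry from one core to the other, for it gives a 5.8-fold higher number from compound 3 to compound 4 (0.76 log units; beyond the scatter), against the opposite direction on the first core: the same change on two cores in this assay, an at least 15-fold lower number (1.19 log units; beyond the scatter) from compound 2 to compound 1 and a 5.8-fold higher number (0.76 log units; beyond the scatter) from compound 3 to compound 4, at least 90-fold (1.95 log units) apart, beyond the scatter of two such steps. The change of amide group also depends on its partner, as 1,3-thiazol-2-yl in place of 5-methyl-1,2-oxazol-3-yl gives a 1.7-fold lower number from compound 1 to compound 4 (0.24 log units; within the scatter) when chloro is on the ring: the same change on two cores in this assay, an at least 150-fold lower number (2.19 log units; beyond the scatter) from compound 2 to compound 3 and a 1.7-fold lower number (0.24 log units; within the scatter) from compound 1 to compound 4, at least 90-fold (1.95 log units) apart, beyond the scatter of two such steps. On these data alone, both earlier steps start from compound 2, whose value is only a limit, so their true sizes remain unknown, and two cores show that the change failed to carry over here, not how it would behave on a further core: the limit of > 30000 nM in this assay, at which 1 of the 4 values shown sits.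

The compounds shown leave open whether the reversed step belongs to the 1,3-thiazol-2-yl amide alone or would also appear with another group on the amide nitrogen. They also leave open how a methoxy group or a plain hydrogen in place of the halogen would read in this assay on either core.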